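The compounds below may be only part of what the source reports. "The series", "measured", "known", "first", "only" and "open" are said of these compounds alone.

Compound 2 `CCOC(=O)N1CCC(=NNC(=O)c2ccc(C(F)(F)F)cc2)CC1` stands at the lower of the two numbers in a functional assay, read by spectrophotometry, with a stated time of 2 h (a higher number here means a weaker inhibitor, a lower number a stronger inhibitor), where compound 2 gives 33800 nM; compound 1 `CCOC(=O)N1CCC(=NNC(=O)c2ccc(C)cc2)CC1` gives 75500 nM, and the step of a 2.2-fold lower number from compound 1 to compound 2 (0.35 log units; beyond the scatter) is the only measured one in the series. Compound 3 `CCOC(=O)N1CCC(=NNC(=O)c2ccc([N+](=O)[O-])cc2)CC1` differs from compound 2 by nitro in place of trifluoromethyl on an aromatic carbon. Among the measured compounds shown here, no measured step exchanges trifluoromethyl for nitro, so the step from compound 1 to compound 2 shows only that one change at this position moved the number modestly. Compound 3 is expected to shift by a 1.4-fold lower number from compound 2 to compound 3 (0.13 log units; within the scatter), at most slightly lower. Compound 3 is estimated at 25000 nM, within 8000 nM to 80000 nM.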

Compound 3, half-maximal inhibitory concentration: 51700 nM
Compound 3: the middle estimate sits 2.1-fold (0.32 log units) below what was measured; the measured number falls inside the stated range.
By their numbers in this assay, from the lowest: compounds 2, 3 and 1 (each within the scatter of the next, the first and the last beyond it).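

In this assay, the nitro group does not separate from either of the other two groups at this position: a 1.5-fold higher number from compound 2 to compound 3 (0.18 log units; within the scatter) and a 1.5-fold lower number from compound 1 to compound 3 (0.16 log units; within the scatter) both stay within the scatter. Among the compounds shown here, only the step from methyl to trifluoromethyl clears the scatter, so compound 3 sits unresolved between compound 1 and compound 2 and adds no clear trend across the three groups. No evidence is available to explain these numbers. Still open, going by these compounds, is whether an amine, a carboxylic acid or a longer alkyl chain at this position would move the number well outside this narrow band.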